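This account rests on a few compounds, and the source may have more. Where it says the series, first, only, none or still open, it means among the compounds named here.

Compound 2 `CC1(C)C=C(n2ccccc2=O)c2cc(C(=O)c3ccco3)ccc2O1` carries a (furan-2-yl)carbonyl group on the shared core and gives the lowest of the three measured numbers in a functional assay (trachea) with Rattus norvegicus as the target (on this read-out lower numbers stand for lower potency and higher numbers for higher potency (the scale is a negative logarithm)), at 5.92. Its nearest neighbour is compound 3 `Cc1ccccc1C(=O)c1ccc2c(c1)C(n1ccccc1=O)=CC(C)(C)O2`, which gives 6.25 in this assay, and the furthest is compound 1 `CC(=O)c1ccc2c(c1)C(n1ccccc1=O)=CC(C)(C)O2`, which gives 6.65 in this assay. All three differ only in the group on the carbonyl carbon, and every measured step changes that group: a number 0.73 log units lower from compound 1 to compound 2 (beyond the scatter), a number 0.40 log units lower from compound 1 to compound 3 (beyond the scatter) and a number 0.33 log units higher from compound 2 to compound 3 (beyond the scatter). The smallest of the three groups, methyl in compound 1, goes with the highest number, and the furan-2-yl of compound 2 with the lowest.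

Compound 4 `CC1(C)C=C(n2ccccc2=O)c2cc(C=O)ccc2O1` has not yet been measured. It differs from compound 2 as follows: hydrogen in place of furan-2-yl on a carbonyl carbon. This removes the furan-2-yl group outright, leaving a formyl group, which is a smaller group than any of the three measured ones. The three measured steps therefore bear directly on it, and they were all modest. On that basis compound 4 is expected to give a number close to that of compound 1, a rise of about a number 0.53 log units higher from compound 2 to compound 4 (beyond the scatter) beyond the scatter. The estimate for compound 4 in this assay is 6.45, with a range from 5.9 to 7.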

Compound 4, logarithm of the reciprocal of the active concentration, log(1/C): 6.14
Beside the measured number, compound 4's estimate is 0.31 log units above it; the measured number falls inside the stated range.
By their numbers in this assay, from the lowest: compounds 2, 4 and 3 (each within the scatter of the next, the first and the last beyond it); then compound 1.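

In this assay the change to hydrogen on the carbonyl carbon gives a number 0.22 log units higher from compound 2 to compound 4 (within the scatter) and a number 0.11 log units lower from compound 3 to compound 4 (within the scatter), so the formyl group cannot be told apart from either the furan-2-yl or the 2-methylphenyl group, whereas methyl remains distinct, with a number 0.51 log units lower from compound 1 to compound 4 (beyond the scatter). The three earlier compounds allowed a reading in which a smaller group on the carbonyl carbon goes with a higher number, but compound 4, which carries only hydrogen there, goes against that reading, and among the four compounds compound 1 alone stands apart from the rest. Nothing available explains why methyl stands apart from the other groups at this position.

The compounds shown leave open whether a longer chain such as ethyl or propyl on the carbonyl carbon would stay with compound 1 or fall with the others, since the high number rests on methyl alone. They also leave open how an amine in this place, forming an amide, or a hydroxyl group, forming a carboxylic acid, would read.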